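The source may report more compounds than this note shows. Statements on the series, on what has been measured and on what is new or still open speak of the compounds shown alone.

Measured compounds:
- compound 1, `Cc1cc(-c2ccc(O)cc2)c2ncc(CSCCc3ccccc3)n2c1`: 20 ug/mL
- compound 2, `Cc1cc(-c2cccc(C#N)c2)cn2c(CSCCc3ccccc3)cnc12`: > 100 ug/mL
- compound 3, `Cc1cc(-c2cccs2)c2ncc(CSCCc3ccccc3)n2c1`: 100 ug/mL

These three share one core and differ in the aromatic group attached to it. In an ADME assay on HEL cells (Homo sapiens) for cytotoxicity, with a stated time of 3 days (on this read-out higher numbers stand for lower toxicity in this test and lower numbers for higher toxicity in this test), compound 2 gives > 100 ug/mL, which is a limit of the test rather than a number, because the reading sits at the limit of > 100 ug/mL in this assay, at which 1 of the 3 values shown sits. Compound 1 gives 20 ug/mL in this assay, the lowest of the three numbers, and compound 3 gives 100 ug/mL.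

Compound 4, `Cc1cc(-c2ccccc2O)cn2c(CSCCc3ccccc3)cnc12`, has not yet been measured. It differs from compound 2 in one place: 2-hydroxyphenyl in place of 3-cyanophenyl on an aromatic carbon.

Among the compounds with values here, only one measured step bears on this change, and only loosely: a 5.0-fold higher number from compound 1 to compound 3 (0.70 log units; beyond the scatter). There a 4-hydroxyphenyl gave the lower number and its replacement raised it. Compound 4 brings in a 2-hydroxyphenyl, a related group, so a number lower than the limit seen for compound 2 seems more likely than not, though the exact size of an at least 2.0-fold lower number from compound 2 to compound 4 (0.30 log units; that floor lies within the scatter) cannot be read from a limit and is only an expectation. Compound 4 is therefore expected to give about 50 ug/mL in this assay, with an estimated range from 20 ug/mL to 100 ug/mL.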

Compound 4, minimum cytotoxic concentration: 100 ug/mL
Estimate against measurement, compound 4: 2.0-fold (0.30 log units) below; low and high end bracket the measured number.
By their numbers in this assay, from the lowest: compound 1; then compounds 3 and 4 (each within the scatter of the next).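

In this assay compound 2 gives > 100 ug/mL, which is a limit of the test and not a number. The change is a number no higher from compound 2 to compound 4 (the limit leaves the size open), because the reading sits at that limit: the limit of > 100 ug/mL in this assay, at which 1 of the 4 values shown sits. Within the data shown here, compound 4 gives 100 ug/mL, the first actual number for an aromatic group on this carbon, para to a fused ring and meta to a methyl group, and it shows that a 2-hydroxyphenyl, which brings a hydrogen-bond donor that 3-cyanophenyl does not have, can sit here with a reading on the low-toxicity side of this test. Compound 1 also carries a hydroxyl on its phenyl ring, but it differs from compound 4 in more than one place, so its lower number cannot be carried over to this position.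

The compounds shown leave open whether the reading of compound 4 comes from the hydroxyl or simply from the phenyl ring that carries it, a question that a plain phenyl on this carbon would address. They also do not show what a 2-aminophenyl or a group with a carboxylic acid would do at this position.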